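The source may report more compounds than this note shows. Statements on the series, on what has been measured and on what is new or still open speak of the compounds shown alone.

Measured so far:
Compound 1: `N=C(N)N/N=C/c1c(-c2cccs2)nc2n1CCS2` gives 19100 nM
Compound 2: `N=C(N)N/N=C/c1c(-c2cccs2)nc2sccn12` gives 12000 nM

Both compounds were tested in a functional assay on cells (Cancer cell lines, Homo sapiens) for inhibition; a higher number here means a weaker inhibitor of growth, a lower number a stronger inhibitor of growth. Compound 2 shows the lower of the two numbers, but its distance from compound 1 is within the usual scatter of repeated measurements, so the two cannot be told apart on these data alone; both are weak inhibitors of growth. Among the measured compounds shown here, no pair differing in only one place has been measured, so there is no measured step to lean on.

Compound 3, `N=C(N)N/N=C/c1c(-c2ccsc2)nc2sccn12`, has not yet been measured. It differs from compound 2 in one place: thiophen-3-yl in place of thiophen-2-yl on an aromatic carbon. The two compounds contain the same atoms, joined differently, and the change keeps the same ring with the same single hetero atom, only attached at a different point.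

For the measured compounds named here, with no measured step of this kind available, the expectation is that the step from compound 2 to compound 3, no change at the digits printed from compound 2 to compound 3 (within the scatter), stays within the scatter rather than moving clearly in either direction. Compound 3 is therefore estimated at 12000 nM in this assay, with a range from 4000 nM to 36000 nM.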

Compound 3, concentration for 50% growth inhibition: 15100 nM
Estimate against measurement, compound 3: 1.3-fold (0.10 log units) below, and the stated range covers the measured number.
By their numbers in this assay, from the lowest: compounds 2, 3 and 1 (each within the scatter of the next).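

Moving the attachment point of the thiophene on the aromatic carbon, with thiophen-3-yl in place of thiophen-2-yl, gives in this assay a 1.3-fold higher number from compound 2 to compound 3 (0.10 log units; within the scatter), so this change cannot be told apart from no change at all. Among the compounds shown here, this is the only measured step at this position, and it shows that switching the point at which the thiophene ring is joined to the shared core leaves no detectable shift in growth inhibition, with compound 2 and compound 3 both remaining weak inhibitors. Nothing else shown here helps to explain why the two read alike.

Since both compounds carry the same ring with the same single sulfur atom, the data say nothing about how this position responds to a truly different group, such as a phenyl ring, a methyl group or an amine. Going by these compounds, it also remains open whether the same swap would read alike on the core of compound 1, and whether any group at this position can move growth inhibition clearly beyond the scatter.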